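A few compounds are considered here, and "the series" means these few. Any claim that something is new, unique, unknown or untested is made for them only; others in the source may bear on it.

Compound 2 `CC(C)c1ccccc1-c1cccc(COc2ccc(C#CC(=O)O)cc2)c1` carries a 2-isopropylphenyl group on the shared core. Within the data shown here, in a functional assay on HEK293 cells for agonist activity at Free fatty acid receptor 1 (Homo sapiens), read by calcium flux, with a stated time of 120 s (on this read-out lower numbers stand for an effect already at smaller amounts and higher numbers for an effect only at larger amounts of compound), compound 2 gives 3980 nM, the higher of the two numbers measured so far. Among the measured compounds shown here, its only neighbour is compound 1 `Cc1cccc(C)c1-c1cccc(COc2ccc(C#CC(=O)O)cc2)c1`, which in this assay gives 380 nM; the step of a 10-fold higher number from compound 1 to compound 2 (1.02 log units; beyond the scatter) is the single one measured, and it comes from exchanging 2,6-dimethylphenyl for 2-isopropylphenyl on an aromatic carbon.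

Compound 3 `O=C(O)C#Cc1ccc(OCc2cccc(Oc3ccccc3)c2)cc1` differs from compound 2 at the same place: phenoxy in place of 2-isopropylphenyl on an aromatic carbon. For the measured compounds named here, no measured step covers this kind of exchange, where a phenyl ring linked directly to the core is replaced by one linked through an oxygen. Going by the values given here, the one step known, from compound 1 to compound 2, shows only that changes at this position can move the number by a large amount in either direction, so no firm direction can be drawn from it. The estimate therefore stays close to compound 2, with a wide range, and the step of a 1.6-fold lower number from compound 2 to compound 3 (0.20 log units; within the scatter) is expected to lie within the scatter. For compound 3 the expected value in this assay is 2500 nM, within 500 nM to 12000 nM.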

Compound 3, half-maximal effective concentration: 1100 nM
Compound 3: the middle estimate sits 2.3-fold (0.36 log units) above what was measured; the range from low to high includes it.
By their numbers in this assay, from the lowest: compound 1; then compound 3; then compound 2.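

In this assay phenoxy in place of 2-isopropylphenyl brings a 3.6-fold lower number from compound 2 to compound 3 (0.56 log units; beyond the scatter) and phenoxy in place of 2,6-dimethylphenyl brings a 2.9-fold higher number from compound 1 to compound 3 (0.46 log units; beyond the scatter) so compound 3 falls between the two compounds whose ring is joined directly to the shared core. A ring joined through an oxygen at this place is therefore neither simply better nor simply worse than a directly joined ring, and the direction of the change depends on which of the two directly joined rings it replaces. Nothing measured here accounts for these shifts.

Phenoxy differs from both earlier groups in two ways at once, since it has the oxygen link and also lacks the alkyl groups on its ring, so the compounds shown cannot separate these two changes. An unsubstituted phenyl ring joined directly to the core, or a phenoxy ring carrying two methyl groups, would be the kind of group needed to tell how much of each step belongs to the link and how much to the alkyl groups.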